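The source may hold more compounds than are shown below. What is called first, only, known or untested is meant among the compounds shown, and "the series" means these compounds.

Working notes on the series. Compound 1 `COc1ccc(/C=C/C(=O)c2ccc(OC)c3c2OC(C)(C)C=C3)cc1OCCO` and compound 2 `COc1ccc(/C=C/C(=O)c2ccc(OC)c3c2OC(C)(C)C=C3)cc1OC(=O)CCl` share one core and differ only in the group on an oxygen on an aromatic ring. Among the measured compounds shown here, in a functional assay on A-375 cells (Homo sapiens) for cytotoxicity, read by MTT assay (on this read-out lower numbers stand for stronger inhibition and higher numbers for weaker inhibition), compound 1 gives 9600 nM, while compound 2 gives 450 nM, the lowest of the two numbers so far.

Next is compound 3 `COc1ccc(/C=C/C(=O)c2ccc(OC)c3c2OC(C)(C)C=C3)cc1OC(=O)C1CC1`, whose difference from compound 2 is cyclopropyl in place of chloromethyl on a carbonyl carbon. In short, cyclopropyl stands in place of chloromethyl on a carbonyl carbon. For the measured compounds named here, the only measured step is a 21-fold lower number from compound 1 to compound 2 (1.33 log units; beyond the scatter), and it bears on this change only in part. It brought in the whole (chloromethyl)carbonyl, and compound 3 keeps the carbonyl but loses the chloromethyl. Going by the values given here, the data do not show how much of that large step goes with either part, and no measured compound isolates the chloromethyl swap.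

A step smaller than the measured one is therefore expected in this assay, more likely toward a higher number, with the range reaching back to about the value of compound 2. The expected change is a 2.4-fold higher number from compound 2 to compound 3 (0.39 log units; beyond the scatter). For compound 3 the estimated value is 1100 nM, with an expected range of 300 nM to 4500 nM.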

Compound 3, half-maximal inhibitory concentration: 380 nM
Compound 3: middle estimate off by 2.9-fold (0.46 log units), on the high side; the measured number falls inside the stated range.
By their numbers in this assay, from the lowest: compounds 3 and 2 (each within the scatter of the next); then compound 1.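

The change shows a 1.2-fold lower number from compound 2 to compound 3 (0.07 log units; within the scatter) in this assay and so places compound 2 and compound 3 on one level, which means that at this carbonyl carbon cyclopropyl can stand in place of chloromethyl with no readable difference. The series also shows a 25-fold lower number from compound 1 to compound 3 (1.40 log units; beyond the scatter) and so the large step away from the 2-hydroxyethyl compound does not depend on chloromethyl, since it also appears with cyclopropylcarbonyl, a group that holds no chlorine. Nothing available explains why these two groups read alike or why both differ so far from 2-hydroxyethyl.

Compound 2 and compound 3 both carry the carbonyl and compound 1 carries none, so the compounds shown do not separate the contribution of the carbonyl itself from that of the group on it. From the compounds shown here alone, it also remains open whether this level holds for quite different groups on that carbonyl carbon, such as an amine or a longer chain, or whether the tolerance seen with chloromethyl and cyclopropyl ends there.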